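Chloro to Trifluoromethyl: An Estimate of Metabolic Stability

The source may report more compounds than this note shows. Statements on the series, on what has been measured and on what is new or still open speak of the compounds shown alone.

Measured compounds:
compound 1, `COc1cc(Br)c2nnn(CC3CC3)c2c1` — "not determined" (no result reported)
compound 2, `Clc1cccc2c1nnn2CC1CC1` — 0.5 mL/min/g

Among the measured compounds shown here, in an ADME assay on microsomes from liver (Rattus norvegicus, strain Wistar) for metabolic stability, tested at 2.5 uM (a lower number here means slower removal, a higher number faster removal of the compound), compound 2 gives 0.5 mL/min/g, the only number in hand; for compound 1 no result was reported, so compound 2 stands alone on the scale. Compound 3, `FC(F)(F)c1cccc2c1nnn2CC1CC1`, carries trifluoromethyl in place of chloro on an aromatic carbon. For the measured compounds named here, no step between two measured compounds is available, so this change is judged without precedent. The step from compound 2 to compound 3 is expected to be a 1.3-fold lower number from compound 2 to compound 3 (0.10 log units; within the scatter), a difference no larger than the usual scatter. Compound 3 is therefore estimated at 0.4 mL/min/g, within 0.2 mL/min/g to 1 mL/min/g in this assay.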

Compound 3, intrinsic clearance in a liver preparation (reported as CLH), per the amount of preparation that the assay uses: 0.3 mL/min/g
Compound 3: middle estimate off by 1.3-fold (0.12 log units), on the high side; the range from low to high includes it.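

Among the compounds shown here, this is the first step that can be read at this position: in this assay, trifluoromethyl in place of chloro on an aromatic carbon gives a 1.7-fold lower number from compound 2 to compound 3 (0.22 log units; within the scatter). Going from 1 heavy atom to 4 at this aromatic carbon therefore leaves the read-out within the usual scatter. No measurement shown here speaks to why this is so. From the compounds shown here alone, how an amine or a carboxylic acid at this aromatic carbon would read remains open. So does whether this step would hold on a core carrying a longer chain.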